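The source may hold more compounds than are shown below. What is called first, only, known or untested is meant among the compounds shown, and "the series" means these compounds.

The measured compounds in a functional assay on the whole organism (artery, strain albino) with Rattus norvegicus as the target, with a stated time of 60 min, at a dose of 10 mg/kg by the oral route (on this read-out higher numbers stand for more inhibition at the one dose given (going by the name of the read-out) and lower numbers for less inhibition), are:

Compound 1, `CC1=C(C(=O)Nc2ccc(Br)cc2)C(c2ccc(Cl)cc2Cl)N=C(SCc2ccccc2)N1`, giving 6.7%.
Compound 2, `CC1=C(C(=O)Nc2ccc(Br)cc2)C(c2ccc(Cl)cc2Cl)N=C(SCc2ccccc2Cl)N1`, giving 11.8%.
Compound 3, `COc1ccc(C2N=C(SCc3ccccc3)NC(C)=C2C(=O)Nc2ccc(Br)cc2)cc1`, giving 5.6%.

Compound 3 has the lowest of the three numbers in this assay, but its neighbours lie close: the step of a number 1.1 percentage points lower from compound 1 to compound 3 (within the scatter) is within the scatter, and compound 2 sits only somewhat higher, again within the scatter. All three values are small on this read-out.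

Compound 4, `COc1ccc(C2N=C(SCc3ccccc3Cl)NC(C)=C2C(=O)Nc2ccc(Br)cc2)cc1`, is not yet measured. It differs from compound 3 by one change, (chloro in place of hydrogen on an aromatic carbon). The same change has been made once before in this series, on the pair of compound 1 and compound 2, where it gave a number 5.1 percentage points higher from compound 1 to compound 2 (within the scatter). That single step bears directly on the present one. Since it stayed within the scatter, a step of similar size is expected here: a number 4.4 percentage points higher from compound 3 to compound 4 (within the scatter), not beyond the scatter. Compound 4 is therefore expected to give 10% in this assay, with a range from 0% to 22%.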

Compound 4, a percentage reported as inhibition, in the whole organism at one dose (the size of the read-out at that dose, not a potency): 6.7%
For compound 4 the middle estimate is 3.3 percentage points above the measured one; low and high end bracket the measured number.
By their numbers in this assay, from the lowest: compounds 3, 1, 4 and 2 (each within the scatter of the next).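

With chloro in place of hydrogen on the core of compound 3, the step is a number 1.1 percentage points higher from compound 3 to compound 4 (within the scatter), so this change on the benzyl group now has a second reading in this assay and again stays within the scatter: the same change on two cores in this assay, a number 5.1 percentage points higher (within the scatter) from compound 1 to compound 2 and a number 1.1 percentage points higher (within the scatter) from compound 3 to compound 4, 4 percentage points apart, within the scatter of two such steps

The change from 2,4-dichlorophenyl to 4-methoxyphenyl also gains a second reading, a number 5.1 percentage points lower from compound 2 to compound 4 (within the scatter), which is likewise within the scatter: the same change on two cores in this assay, a number 1.1 percentage points lower (within the scatter) from compound 1 to compound 3 and a number 5.1 percentage points lower (within the scatter) from compound 2 to compound 4, 4 percentage points apart, within the scatter of two such steps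

Across the four compounds shown, neither change moves the read-out beyond the scatter, whichever group the other place carries.

Whether any group on this aromatic carbon could do so stays open, since the compounds shown carry only hydrogen or chloro there and say nothing about a methoxy group, a nitrile or an amine. As far as these compounds go, how these compounds would compare at other doses also stays open, as the read-out comes from one dose only.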